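Lengthening the Chain on the Triple-Bonded Carbon

This account rests on a few compounds, and the source may have more. Where it says the series, first, only, none or still open, it means among the compounds named here.

Compound 3 `C[C@H](C#Cc1cccc(C(=O)NCc2ccccc2C(F)(F)F)c1)N(O)C(N)=O` gives 600 nM in an assay for inhibition of Polyunsaturated fatty acid 5-lipoxygenase (Homo sapiens), read by HPLC, with stated times of 15 min and 10 min (on this read-out higher numbers stand for weaker inhibition and lower numbers for stronger inhibition), level with compound 1 `CC(C)CC(C#Cc1cccc(C(=O)NCc2ccccc2C(F)(F)F)c1)N(O)C(N)=O` at 600 nM and within the scatter of compound 2 `CCC(C#Cc1cccc(C(=O)NCc2ccccc2C(F)(F)F)c1)N(O)C(N)=O` at 500 nM; the step of a 1.2-fold higher number from compound 2 to compound 3 (0.08 log units; within the scatter) and the step of no change at the digits printed from compound 1 to compound 3 (within the scatter) both stay inside the usual spread. Compound 4 `CCCC(C#Cc1cccc(C(=O)NCc2ccccc2C(F)(F)F)c1)N(O)C(N)=O` carries 1-(carbamoyl(hydroxy)amino)butyl in place of 1-(carbamoyl(hydroxy)amino)ethyl on a triple-bonded carbon. Every measured step alters this same chain in the same place, and a 1.2-fold lower number from compound 1 to compound 2 (0.08 log units; within the scatter), like the two already named, remained within the scatter. Nothing in these numbers points to a change beyond the scatter in this assay, so the expected step is a 1.1-fold lower number from compound 3 to compound 4 (0.04 log units; within the scatter). In this assay compound 4 is estimated at 550 nM, with a range from 280 nM to 1100 nM.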

Compound 4, half-maximal inhibitory concentration: 300 nM
Estimate against measurement, compound 4: 1.8-fold (0.26 log units) above, and the stated range covers the measured number.
By their numbers in this assay, from the lowest: compounds 4, 2, 1 and 3 (each within the scatter of the next).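

In this assay this position stays flat even with the 1-(carbamoyl(hydroxy)amino)butyl chain on the triple-bonded carbon: all three steps to the new compound remain inside the usual spread (a 2.0-fold lower number from compound 3 to compound 4 (0.30 log units; within the scatter); a 1.7-fold lower number from compound 2 to compound 4 (0.22 log units; within the scatter); a 2.0-fold lower number from compound 1 to compound 4 (0.30 log units; within the scatter)). The unbranched butyl chain thus does not separate from the ethyl, propyl or 3-methylbutyl chains. No measurement here bears on why these chains read alike.

From the compounds shown here alone, whether a longer chain such as pentyl, a cyclopropyl ring or an amine on this carbon would move the number beyond the scatter stays open. So does the role of the defined stereocentre, which only compound 3 carries.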